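Anilino ring variation on the shared core: compound 4

The source may report more compounds than this note shows. Statements on the series, on what has been measured and on what is new or still open speak of the compounds shown alone.

Compound 1 `CC(C)c1ccc(-c2nc(SCc3cn(CC(=O)NC(=O)Nc4ccccn4)nn3)nc(Nc3ccc(Cl)cc3)c2C#N)cc1` carries a 4-chlorophenyl on the nitrogen on an aromatic ring of the shared core. In a functional assay on MGC-803 cells (Homo sapiens) for inhibition, read by MTT assay, with a stated time of 72 h (on this read-out higher numbers stand for weaker inhibition and lower numbers for stronger inhibition), compound 1 gives only a limit, > 64000 nM; on the numbers shown it stands at that limit and nowhere firmer (the limit of > 64000 nM in this assay, at which 1 of the 3 values shown sits). Compound 2 `CC(C)c1ccc(-c2nc(SCc3cn(CC(=O)NC(=O)Nc4ccccn4)nn3)nc(Nc3ccccc3)c2C#N)cc1` gives 15800 nM in this assay, and compound 3 `Cc1ccccc1Nc1nc(SCc2cn(CC(=O)NC(=O)Nc3ccccn3)nn2)nc(-c2ccc(C(C)C)cc2)c1C#N` gives 19000 nM in this assay. Both changes away from the 4-chlorophenyl leave the limit behind: an at least 4.0-fold lower number from compound 1 to compound 2 (0.60 log units; beyond the scatter) and an at least 3.3-fold lower number from compound 1 to compound 3 (0.52 log units; beyond the scatter). Between the two numbered compounds the step of a 1.2-fold higher number from compound 2 to compound 3 (0.08 log units; within the scatter) is within the scatter, so phenyl and 2-methylphenyl read alike here.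

Compound 4 `Cc1cccc(Nc2nc(SCc3cn(CC(=O)NC(=O)Nc4ccccn4)nn3)nc(-c3ccc(C(C)C)cc3)c2C#N)c1` differs from compound 1 in one place: 3-methylphenyl in place of 4-chlorophenyl on a nitrogen on an aromatic ring. The measured steps from compound 1 to compound 2 and from compound 1 to compound 3 bear on it, both at least modest and both toward lower numbers, with a methyl on the ring making no difference beyond the scatter in the pair of compound 2 and compound 3. A step of the same kind, toward a lower number and of at least modest size, is therefore expected in this assay, namely an at least 3.7-fold lower number from compound 1 to compound 4 (0.57 log units; beyond the scatter). Compound 4 is expected to give 17000 nM in this assay, with a range from 7000 nM to 40000 nM.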

Compound 4, half-maximal inhibitory concentration: 25300 nM
Beside the measured number, compound 4's estimate is 1.5-fold (0.17 log units) below it; measured number inside the range.
By their numbers in this assay, from the lowest: compounds 2, 3 and 4 (each within the scatter of the next). At a limit, above all of these: compound 1.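

The 3-methylphenyl is a third group on this nitrogen to leave the limit behind in this assay: the change gives an at least 2.5-fold lower number from compound 1 to compound 4 (0.40 log units; beyond the scatter) and so extends the earlier picture beyond phenyl and 2-methylphenyl. Shifting the methyl on the ring gives a 1.3-fold higher number from compound 3 to compound 4 (0.12 log units; within the scatter) and adding it to phenyl gives a 1.6-fold higher number from compound 2 to compound 4 (0.20 log units; within the scatter); both steps lie within the scatter, so among the compounds shown only the 4-chlorophenyl stands apart. Compound 1 still gives a limit and not a number, so the full size of its steps cannot be read: the limit of > 64000 nM in this assay, at which 1 of the 4 values shown sits.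

On these data alone, whether the chlorine itself or its place on the ring sets compound 1 apart stays open, and a 3-chlorophenyl or a 4-methylphenyl on this nitrogen would separate the two. As far as these compounds go, how a ring carrying an amine or a carboxylic acid would read also stays open.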